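The source may hold more compounds than are shown below. What is called first, only, known or untested is meant among the compounds shown, and "the series" means these compounds.

Of the compounds shown here, three built on one shared core have been tested in a functional assay on CCRF-CEM cells (Homo sapiens) for inhibition; a lower number here means a stronger inhibitor, a higher number a weaker inhibitor. Compound 1 `COC(=O)c1ccc(N(C)CC2Cc3c(N)nc(N)nc3NC2=O)cc1` reaches only a limit of the assay in this assay, > 20 ug/mL. Compound 3 `CN(CC1Cc2c(N)nc(N)nc2NC1=O)c1ccc(C(=O)O)cc1` likewise returns only a limit in this assay, > 20 ug/mL. Compound 2 `COC(=O)c1ccc(CCC2Cc3c(N)nc(N)nc3NC2=O)cc1` too gives no number but a limit in this assay, > 20 ug/mL. How the cores of compound 1 and compound 2 differ is not broken down here. From compound 1 to compound 3 the change is hydrogen in place of methyl on an oxygen next to a carbonyl group, and the step that the two limits leave unreadable from compound 1 to compound 3, since both values sit at the limit of > 20 ug/mL in this assay, at which 3 of the 3 values shown sit. Compound 4 `Nc1nc(N)c2c(n1)NC(=O)C(CCc1ccc(C(=O)O)cc1)C2` has not been measured; it differs from compound 2 by hydrogen in place of methyl on an oxygen next to a carbonyl group, the same change in the same place. The step that the limit leaves unreadable from compound 2 to compound 4 is expected to be small, which rests on compound 1 and compound 3 both sitting at the limit of > 20 ug/mL in this assay, at which 3 of the 3 values shown sit, and on compound 2 itself sitting there. For compound 4 in this assay the estimate is therefore 30 ug/mL, with a range from 10 ug/mL to 100 ug/mL, most likely reported again as a limit rather than a number.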

Compound 4, half-maximal inhibitory concentration: 6.7 ug/mL
Compound 4: the middle estimate sits 4.5-fold (0.65 log units) above what was measured; measured number below the stated range.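

In this assay, as far as these compounds go, the change from methoxycarbonyl to carboxy on the core of compound 2 gives an at least 2.9-fold lower number from compound 2 to compound 4 (0.47 log units; beyond the scatter), so on this core the change goes with a stronger inhibitor, and the true size of the step stays open, as one end of it is a limit. On the core of compound 1, the same change leaves a step that cannot be read, as both of its ends are limits. The change is therefore shown to work on one core only, and the series shows neither that it carries over from one core to the other nor that it fails to: the limit of > 20 ug/mL in this assay, at which 3 of the 4 values shown sit.

The compounds shown leave open whether the gain depends on the carboxylic acid itself, as no amide, ethyl ester or tetrazole stands in its place on the core of compound 4. Among the compounds shown here, they also leave open how a longer chain in place of the one in compound 4 would read in this assay.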